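A few compounds are considered here, and "the series" means these few. Any claim that something is new, unique, unknown or untested is made for them only; others in the source may bear on it.

Among the measured compounds shown here, compound 1, with the structure `C[C@@H](CNc1ccc(OC(F)(F)F)cc1)NC(=O)[C@H](CCC1CCCCC1)CC(=O)N1CCOCC1`, is one of two compounds measured in an assay on isolated protein for inhibition of cathepsin S (Homo sapiens) (a higher number here means a weaker inhibitor, a lower number a stronger inhibitor), where compound 1 gives 95 nM. The other is compound 2, with the structure `CS(=O)(=O)CC[C@H](CNc1ccc(OC(F)(F)F)cc1)NC(=O)[C@@H](CC(=O)N1CCOCC1)CC1CCCCC1`, and in this assay compound 2 gives 69 nM. On these two numbers compound 1 sits at the top, but compound 2 lies so close that the gap between them falls within the usual scatter, so the two cannot be told apart.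

Compound 3, with the structure `C[C@@H](CNc1ccc(OC(F)(F)F)cc1)NC(=O)[C@@H](CC(=O)N1CCOCC1)CC1CCCC1`, has not yet been measured. It differs from compound 1 in one place: cyclopentyl in place of cyclohexylmethyl on a saturated chain carbon, two bonds along the chain from a carbonyl carbon. For the measured compounds named here, no measured pair shows this change, so its effect is unknown; the expectation is a modest step toward a weaker inhibitor, with the step from compound 1 to compound 3 estimated at a 2.1-fold higher number from compound 1 to compound 3 (0.32 log units; beyond the scatter). Compound 3 is therefore expected to give about 200 nM in this assay, within a range from 80 nM to 600 nM.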

Compound 3, inhibition constant: 31 nM
Compound 3: middle estimate off by 6.5-fold (0.81 log units), on the high side; measured number below the stated range.
By their numbers in this assay, from the lowest: compound 3; then compounds 2 and 1 (each within the scatter of the next).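

The chain carbon two bonds along from a carbonyl carbon turns out to be sensitive to what it carries: in this assay, cyclopentyl in place of cyclohexylmethyl gives a 3.1-fold lower number from compound 1 to compound 3 (0.49 log units; beyond the scatter) and so moves toward a stronger inhibitor. Among the compounds shown here, this is the first single-place change available here, and it shows that a group with five carbons instead of seven, and a five-membered ring instead of a six-membered one, is tolerated at this position and does not cost strength. Nothing available here explains why the number falls.

Ring size and chain length change together in this step, so a single pair cannot show which of them matters. A 2-cyclopentylethyl group would keep the chain of compound 1 with the smaller ring, while a phenyl ring would test whether this position needs a saturated ring at all.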